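A few compounds are considered here, and "the series" means these few. Any claim that something is new, unique, unknown or untested is made for them only; others in the source may bear on it.

Compound 1: `COc1cc(/C=C2\Cc3ccccc3/C(=C\c3ccc([N+](=O)[O-])cc3)C2=O)ccc1O`, 5800 nM
Compound 2: `COc1ccc(/C=C2\Cc3ccccc3/C(=C\c3ccc([N+](=O)[O-])cc3)C2=O)cc1`, 47000 nM

In a functional assay on HSG cells (Homo sapiens) for cytotoxicity (on this read-out lower numbers stand for higher toxicity in this test and higher numbers for lower toxicity in this test), compound 2 stands at the higher of the two numbers, with compound 1 giving the only lower one: an 8.1-fold higher number from compound 1 to compound 2 (0.91 log units; beyond the scatter). Compound 3, `COc1ccc(/C=C2\Cc3ccccc3/C(=C\c3ccc([N+](=O)[O-])cc3)C2=O)cc1OC`, arises from compound 2 by methoxy in place of hydrogen on an aromatic carbon. Within the data shown here, the one step known here does not test this change alone, since it also swaps the hydroxyl for methoxy, so the direction is uncertain. Compound 3 is expected to fall between the two measured numbers, at 20000 nM (range 6000 nM to 60000 nM), a step of a 2.4-fold lower number from compound 2 to compound 3 (0.37 log units; beyond the scatter).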

Compound 3, half-maximal cytotoxic concentration: 4400 nM
Compound 3: the middle estimate sits 4.5-fold (0.66 log units) above what was measured; the measured number lies below the stated range.
By their numbers in this assay, from the lowest: compounds 3 and 1 (each within the scatter of the next); then compound 2.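

In this assay, methoxy on the aromatic carbon ortho to a methoxy group gives an 11-fold lower number from compound 2 to compound 3 (1.03 log units; beyond the scatter) and so shows that this position alone can carry a large step, with no hydroxyl present. Methyl in place of the hydroxyl hydrogen gives a 1.3-fold lower number from compound 1 to compound 3 (0.12 log units; within the scatter) and leaves 3,4-dimethoxyphenyl and 4-hydroxy-3-methoxyphenyl unseparated in this test. Nothing available here accounts for either step. From the compounds shown here alone, whether an ethoxy group, a chlorine or an amine at this position would match methoxy remains open. So does the outcome with hydroxyl there and methoxy removed from the neighbouring carbon's group.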